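Hydrazone series: 3,5-dimethoxyphenyl analogue outlook

The compounds below may be only part of what the source reports. "The series", "measured", "known", "first", "only" and "open" are said of these compounds alone.

Measured so far:
compound 1 `COc1ccc(O)c(/C=N/NC(=O)c2ccc(-c3nc4ccccc4s3)cc2)c1`: 6500 nM
compound 2 `COC(=O)c1ccc(/C=N/NC(=O)c2ccc(-c3nc4ccccc4s3)cc2)cc1`: "not active" (no number reported)

In an assay on isolated protein for inhibition of Maltase-glucoamylase (Homo sapiens), with a stated time of 15 min (on this read-out lower numbers stand for stronger inhibition and higher numbers for weaker inhibition), compound 1 gives 6500 nM. Compound 2 is recorded as "not active" (no number reported) in this assay, so no single number stands for it; it can only be placed as giving no measurable inhibition under the conditions used. Among the measured compounds shown here, no step between measured compounds can therefore be quantified.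

Compound 3 `COc1cc(/C=N/NC(=O)c2ccc(-c3nc4ccccc4s3)cc2)cc(OC)c1` is the next member. It differs from compound 2 by 3,5-dimethoxyphenyl in place of 4-(methoxycarbonyl)phenyl on a carbon with a double bond to nitrogen. For the measured compounds named here, since compound 2 has no number, no size of step can be stated; the expectation is simply that compound 3 will return a number where compound 2 did not, though one well above the value of compound 1, because compound 1 already gives only 6500 nM. Compound 3 is estimated at 20000 nM, with a range from 5000 nM to 80000 nM.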

Compound 3, half-maximal inhibitory concentration: 16200 nM
Beside the measured number, compound 3's estimate is 1.2-fold (0.09 log units) above it, within the range that was stated.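

In this assay, the exchange of 4-(methoxycarbonyl)phenyl for 3,5-dimethoxyphenyl separates a compound recorded as not active from one with a number, although both groups have the same counts of heavy atoms and hydrogen-bond acceptors; the step between compound 2 and compound 3 cannot be read as a size. Among the compounds shown here, the first readable step on this carbon with a double bond to nitrogen is a 2.5-fold higher number from compound 1 to compound 3 (0.40 log units; beyond the scatter), with 3,5-dimethoxyphenyl in place of 2-hydroxy-5-methoxyphenyl. No available measurement bears on the reason for either difference.

This step does not separate the loss of the hydroxy group from the altered methoxy pattern. On these data alone, how a phenyl ring carrying a carboxylic acid or an amine would read on this carbon remains open.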